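Swapping the ring substituent in a shared anti-inflammatory core

The compounds below may be only part of what the source reports. "The series", "measured", "known", "first", "only" and "open" are said of these compounds alone.

Compound 1 `COc1ccc(C2CC(C3C(=O)c4ccccc4C3=O)=NC(=O)N2)cc1`: 22% in a functional assay on the whole organism for inhibition, with Rattus norvegicus as the target, read by paw edema, with stated times of 30 min and 1 h, at a dose of 10 mg/kg by the oral route; a lower number here means less inhibition, a higher number more inhibition at the dose given (going by the name of the read-out)
Compound 2 `O=C1N=C(C2C(=O)c3ccccc3C2=O)CC(c2ccc([N+](=O)[O-])cc2)N1`: 16% in this assay
Compound 3 `O=C1N=C(C2C(=O)c3ccccc3C2=O)CC(/C=C/c2ccccc2)N1`: 17% in this assay

Compound 3 stands second of the three numbers; its nearest neighbour is compound 2, and the step of a number 1 percentage points higher from compound 2 to compound 3 (within the scatter) is within the scatter, as is the larger gap a number 5 percentage points lower from compound 1 to compound 3 (within the scatter) to compound 1. All three compounds therefore sit in one band that the assay cannot separate.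

Compound 4 `CN(C)c1ccc(C2CC(C3C(=O)c4ccccc4C3=O)=NC(=O)N2)cc1` differs from compound 3 in one place: 4-(dimethylamino)phenyl in place of 2-phenylethenyl on a saturated ring carbon. Among the measured compounds shown here, the steps that bear on this change are those that also alter the group on the saturated ring carbon, namely a number 5 percentage points lower from compound 1 to compound 3 (within the scatter) and a number 1 percentage points higher from compound 2 to compound 3 (within the scatter), and the aromatic substituent swap a number 6 percentage points lower from compound 1 to compound 2 (within the scatter); none of them left the scatter. Compound 4 is therefore expected to show no step beyond the scatter, with a number 3 percentage points higher from compound 3 to compound 4 (within the scatter) as the estimated move, and compound 4 is estimated at 20% in this assay, with a range from 10% to 30%.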

Compound 4, a percentage reported as inhibition, in the whole organism at one dose (the size of the read-out at that dose, not a potency): 15%
Compound 4: the middle estimate sits 5 percentage points above what was measured; the range from low to high includes it.
By their numbers in this assay, from the lowest: compounds 4, 2, 3 and 1 (each within the scatter of the next).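

Dimethylamino in place of nitro on the aromatic carbon gives a number 1 percentage points lower from compound 2 to compound 4 (within the scatter), and dimethylamino in place of methoxy gives a number 7 percentage points lower from compound 1 to compound 4 (within the scatter), so a third group at this carbon also fails to separate from the others in this assay. On the saturated ring carbon, 4-(dimethylamino)phenyl in place of 2-phenylethenyl gives a number 2 percentage points lower from compound 3 to compound 4 (within the scatter), which adds one more replacement at that position that stays within the scatter, and all four compounds now remain in one band. Nothing available explains why these changes leave the read-out within that band.

As far as these compounds go, whether a carboxylic acid on the aromatic carbon or a simple ethyl chain on the saturated ring carbon would move a compound out of this band remains open. A reading at one dose also leaves the potency of these compounds open.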